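Mirror Image of an Acetyl Urea Tested in Rice

A few compounds are considered here, and "the series" means these few. Any claim that something is new, unique, unknown or untested is made for them only; others in the source may bear on it.

Two ureas have been measured in an ADME assay on the whole organism with Oryza sativa as the target, tested at 1 uM; a higher number here means a weaker effect of the compound at the concentration tested, a lower number a stronger effect. Compound 1 `CCc1ccc(NC(=O)N[C@@H](C)c2ccccc2)cc1` gives 95% in this assay, and compound 2 `CC(=O)c1ccc(NC(=O)N[C@H](C)c2ccccc2)cc1` gives 93%; the gap between these two numbers lies within the usual scatter, so the two compounds cannot be told apart on this measure. Compound 2 is the starting point here. The next compound, compound 3 `CC(=O)c1ccc(NC(=O)N[C@@H](C)c2ccccc2)cc1`, keeps every atom and bond of compound 2: the two compounds have the same atoms and bonds and differ only in configuration as drawn: 1 of 1 stereo elements differ; a stereocentre at a saturated chain carbon is drawn R in compound 2 and S in compound 3. Among the measured compounds shown here, no step between two measured compounds that differ in only one place is available, and compound 1 carries the same drawn configuration as compound 3 but a different group on its ring, so it does not show the effect of the configuration alone. With nothing to point to a direction, the step is expected to stay within the scatter, the estimated change being no change at the digits printed from compound 2 to compound 3 (within the scatter). Compound 3 is therefore estimated to give 93% in this assay, within a range from 80% to 100%.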

Compound 3, a percentage reported as activity, at one concentration (the size of the read-out at that concentration, not a potency): 99%
Compound 3: middle estimate off by 6 percentage points, on the low side, within the range that was stated.
By their numbers in this assay, from the lowest: compounds 2, 1 and 3 (each within the scatter of the next).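

Changing only the drawn configuration at the saturated chain carbon from R to S gives, in this assay, a number 6 percentage points higher from compound 2 to compound 3 (within the scatter), so at this one concentration the two mirror-image forms of the acetyl urea cannot be told apart. With the S configuration kept, acetyl in place of ethyl on an aromatic carbon gives a number 4 percentage points higher from compound 1 to compound 3 (within the scatter), so this change of ring group cannot be told from the scatter either. For the first of these steps, the comparison is a clean one, as only a single feature separates the pair: the fact that compounds 2 and 3 differ only in the configuration as drawn

Going by these compounds, whether configuration would matter in a compound with a clearly stronger effect remains open. It is also unknown what an amine or a carboxylic acid in place of the acetyl group would do in this assay.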